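This account rests on a few compounds, and the source may have more. Where it says the series, first, only, none or still open, it means among the compounds named here.

In a functional assay on A549 cells (Homo sapiens) for antiproliferative activity, read by MTT assay, with a stated time of 72 h (a lower number here means a stronger inhibitor, a higher number a weaker inhibitor), compound 2 (`C=CC(=O)Nc1cc2c(Nc3ccc(F)c(Cl)c3)ncnc2cc1OCc1cn(CCC(=O)NO)nn1`) gives > 50000 nM as a limit of the assay, not a number. Compound 1 (`C=CC(=O)Nc1cc2c(Nc3ccc(OCc4cccc(F)c4)c(Cl)c3)ncnc2cc1OCc1cn(CCCCC(=O)NO)nn1`) gives > 50000 nM as a limit too. Compound 2 thus stands at the limit of > 50000 nM in this assay, at which 2 of the 2 values shown sit, and has no measured number of its own. Compound 3 (`C=CC(=O)Nc1cc2c(Nc3ccc(OCc4cccc(F)c4)c(Cl)c3)ncnc2cc1OCc1cn(CCC(=O)NO)nn1`) has (3-fluorobenzyl)oxy in place of fluoro on an aromatic carbon, ortho to a chloro group and para to a large group ((3-fluorobenzyl)oxy in place of fluoro on an aromatic carbon). Among the measured compounds shown here, no measured step shows what this change does. For the measured compounds named here, the only guide is compound 1, which also bears (3-fluorobenzyl)oxy and still reports the limit > 50000 nM in this assay. No shift beyond the scatter is therefore expected in either direction, and the estimate is a number no higher from compound 2 to compound 3 (the limit leaves the size open) in this assay. For compound 3 the estimated value is 50000 nM within an expected range of 15000 nM to 100000 nM in this assay.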

Compound 3, half-maximal inhibitory concentration: > 50000 nM
Compound 3: a limit, no number; the forecaster's own chance of this, stated with the estimate: 70%; the middle value lies on the limit itself.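

Compound 3 gives a limit, not a number, and the steps to it from compound 1 and compound 2 cannot be read: the limit of > 50000 nM in this assay, at which 3 of the 3 values shown sit. The compounds shown leave open whether (3-fluorobenzyl)oxy in place of fluoro, or the chain carrying the hydroxycarbamoyl group, changes antiproliferative activity at all.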